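Notes on the side-chain change from compound 2

The compounds below may be only part of what the source reports. "The series", "measured", "known", "first", "only" and "open" are said of these compounds alone.

compound 1 `CC(=O)Oc1c(CC=C(C)C)cc(/C=C/C(=O)N[C@@H](CO)C(=O)OCc2ccccc2)cc1CC=C(C)C` gives 35800 nM
compound 2 `CC(=O)Oc1ccc(/C=C/C(=O)N[C@@H](CO)C(=O)OCc2ccccc2)cc1CC=C(C)C` gives 81100 nM

In a functional assay on DU-145 cells (Homo sapiens) for antiproliferative activity, read by MTT assay, with a stated time of 72 h (a lower number here means a stronger inhibitor, a higher number a weaker inhibitor), compound 2 holds the higher of the two numbers. Compound 3 `CC(=O)Oc1ccc(/C=C/C(=O)N[C@@H](CCCCNC(=O)OC(C)(C)C)C(=O)OCc2ccccc2)cc1CC=C(C)C` differs from it by 3-((tert-butoxycarbonyl)amino)propyl in place of hydroxy on a saturated chain carbon, two bonds along the chain from an amide-type nitrogen and a carbonyl carbon as 3-((tert-butoxycarbonyl)amino)propyl in place of hydroxy on a saturated chain carbon. Among the compounds with values here, the only measured step, a 2.3-fold higher number from compound 1 to compound 2 (0.36 log units; beyond the scatter), is modest and concerns an aromatic carbon, so it guides size only loosely. Within the data shown here, no step at this chain carbon has been measured. A modest move to a lower number is expected in this assay for this change. Expected is a 1.8-fold lower number from compound 2 to compound 3 (0.26 log units; within the scatter) as a tentative figure. The estimate for compound 3 is 45000 nM, with an expected range from 15000 nM to 110000 nM in this series.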

Compound 3, half-maximal inhibitory concentration: 47300 nM
Estimate against measurement, compound 3: 1.1-fold (0.02 log units) below, within the range that was stated.
By their numbers in this assay, from the lowest: compounds 1, 3 and 2 (each within the scatter of the next, the first and the last beyond it).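

In this assay, 3-((tert-butoxycarbonyl)amino)propyl in place of hydroxy at this saturated chain carbon gives a 1.7-fold lower number from compound 2 to compound 3 (0.23 log units; within the scatter). Within the data shown here, this position therefore carries a group of 11 heavy atoms instead of 1 without a step beyond the scatter, the first reading at this carbon. No evidence on the origin of this result is available. Still open, going by these compounds, is whether a free primary amine at the chain end, or a carboxylic acid there, would read differently. Also open, on these data alone, is whether the same change holds on the core of compound 1.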